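This account rests on a few compounds, and the source may have more. Where it says the series, first, only, none or still open, it means among the compounds named here.

Measured so far:
compound 1, `CCCOC(=O)Nc1ccc([Se]C#N)cc1`: 67500 nM
compound 2, `O=C(Nc1ccc([Se][Se]c2ccc(NC(=O)OCc3ccccc3)cc2)cc1)OCc1ccccc1`: 74500 nM

Both compounds were tested in a functional assay on MCF7 cells (Homo sapiens) for cytotoxicity, read by MTT assay, with a stated time of 72 h; a higher number here means that more compound is tolerated, a lower number that less compound is tolerated. Compound 1 gives 67500 nM, the lower of the two numbers. Compound 2 gives 74500 nM, and the gap between these two values lies within the scatter of the method, so the two compounds cannot be told apart on this evidence.

Compound 3, `CCCCOC(=O)Nc1ccc([Se]C#N)cc1`, has not yet been measured in this assay. It differs from compound 1 in one place: methyl in place of hydrogen on a saturated chain carbon, three bonds along the chain from an oxygen next to a carbonyl group. Put another way, the propyl chain on the carbamate oxygen becomes a butyl chain.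

Among the measured compounds shown here, no step of this kind between measured compounds is available here, so the only guide is the change itself, which adds one carbon to a flexible chain. A step of that size is expected to do little. The change from compound 1 to compound 3 is estimated at a 1.1-fold lower number from compound 1 to compound 3 (0.05 log units; within the scatter), not beyond the scatter in either direction. Compound 3 is therefore expected to give about 60000 nM, with a plausible range from 30000 nM to 120000 nM.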

Compound 3, concentration lethal to 50% of the cells: 59700 nM
For compound 3 the middle estimate is 1.0-fold (0.00 log units) above the measured one; low and high end bracket the measured number.
By their numbers in this assay, from the lowest: compounds 3, 1 and 2 (each within the scatter of the next).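

In this assay, the change from a propyl to a butyl chain on the carbamate oxygen gives a 1.1-fold lower number from compound 1 to compound 3 (0.05 log units; within the scatter) and so provides a direct comparison of two compounds that differ in one place, which compounds 1 and 2 could not offer. At this position, three bonds along the chain from an oxygen next to a carbonyl group, adding one methyl therefore causes no change that can be told apart from the scatter of the method. No measurement shown here speaks to why this is so.

This single step leaves open whether a much longer chain, such as octyl, would also leave the number within the scatter. It also leaves open what an amine or a carboxylic acid at the end of the chain would do.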